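Methoxy for methyl on a second ring position

A few compounds are considered here, and "the series" means these few. Any claim that something is new, unique, unknown or untested is made for them only; others in the source may bear on it.

Measured so far:
compound 1 `Cc1ccccc1C(=O)/C=C/CCc1ccccc1` 2630 nM
compound 2 `Cc1cccc(C(=O)/C=C/CCc2ccccc2)c1` 2570 nM
compound 3 `COc1ccccc1C(=O)/C=C/CCc1ccccc1` 1720 nM

In a functional assay on HEK293 cells for antagonist activity at G-protein coupled receptor 52 (Homo sapiens), read by cAMP accumulation, with stated times of 15 min and 30 min (on this read-out lower numbers stand for stronger inhibition and higher numbers for weaker inhibition), compound 1 gives 2630 nM and compound 3 gives 1720 nM. The change between them, (methoxy in place of methyl on an aromatic carbon), made a step of a 1.5-fold lower number from compound 1 to compound 3 (0.18 log units; within the scatter). Compound 2 and compound 1 share the same atoms joined differently; the difference between the two cores is not broken down here. Compound 4 `COc1cccc(C(=O)/C=C/CCc2ccccc2)c1` has not been measured. It differs from compound 2 by methoxy in place of methyl on an aromatic carbon. This is the same kind of change as from compound 1 to compound 3, but the place differs: there the methoxy sits ortho to a large group, here meta to a large group. Because the earlier step of a 1.5-fold lower number from compound 1 to compound 3 (0.18 log units; within the scatter) stayed within the scatter, a similarly small step is expected here, a 1.5-fold lower number from compound 2 to compound 4 (0.17 log units; within the scatter). Compound 4 is estimated at 1750 nM in this assay, with a range from 900 nM to 3600 nM.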

Compound 4, half-maximal inhibitory concentration: 1490 nM
Beside the measured number, compound 4's estimate is 1.2-fold (0.07 log units) above it; measured number inside the range.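

In this assay, methoxy in place of methyl on the core of compound 2 gave a 1.7-fold lower number from compound 2 to compound 4 (0.24 log units; within the scatter). The same change on the core of compound 1 gave a step that agrees with it: the same change on two cores in this assay, a 1.5-fold lower number (0.18 log units; within the scatter) from compound 1 to compound 3 and a 1.7-fold lower number (0.24 log units; within the scatter) from compound 2 to compound 4, 1.1-fold (0.05 log units) apart, within the scatter of two such steps This shows that the change behaves alike on these two cores, but both steps are small enough that neither separates methoxy from methyl, and two cores cannot show how the change would behave on any other core.

The compounds shown leave open what a clearly different group on the same aromatic carbon, such as an amine or a carboxylic acid, would do. They also leave open whether a longer chain would move the number beyond the scatter.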